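A Trimethylphenyl Replaces a Difluorophenyl on the Thioether Sulfur

The source may hold more compounds than are shown below. What is called first, only, known or untested is meant among the compounds shown, and "the series" means these compounds.

Two compounds have so far been measured in an assay for inhibition of Polyunsaturated fatty acid 5-lipoxygenase (Homo sapiens), read by HPLC, with a stated time of 10 min; on this read-out higher numbers stand for weaker inhibition and lower numbers for stronger inhibition:
Compound 1, `CCOC(=O)c1c(CSc2ccc(OC(F)(F)F)cc2)n(C)c2ccc(O)cc12`, gives 900 nM.
Compound 2, `CCOC(=O)c1c(CSc2ccc(F)cc2F)n(C)c2ccc(O)cc12`, gives 3200 nM.

For the measured compounds named here, compound 2 stands at the highest of these two numbers; its only neighbour on the scale is compound 1, which sits lower by a margin beyond the usual scatter. Going by the values given here, the two differ in the aryl group on the sulfur, but no single-point step between them is computed here, so only their two values can be set side by side. The compound not yet measured is compound 3, `CCOC(=O)c1c(CSc2c(C)cc(C)cc2C)n(C)c2ccc(O)cc12`. It differs from compound 2 in one place: 2,4,6-trimethylphenyl in place of 2,4-difluorophenyl on a sulfur. Among the compounds with values here, nothing among the measured compounds shows how a 2,4,6-trimethylphenyl on the sulfur behaves in this assay, so the direction of the step cannot be read from any precedent. The account therefore expects no step beyond the usual scatter, with only a slight lean toward a lower number, and estimates for compound 3 a value of 2000 nM, between 500 nM and 8000 nM, which corresponds to an expected step of a 1.6-fold lower number from compound 2 to compound 3 (0.20 log units; within the scatter).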

Compound 3, half-maximal inhibitory concentration: 700 nM
Estimate against measurement, compound 3: 2.9-fold (0.46 log units) above; measured number inside the range.
By their numbers in this assay, from the lowest: compounds 3 and 1 (each within the scatter of the next); then compound 2.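

In this assay, for the compounds shown here, the group on the sulfur can shift the number beyond the scatter: 2,4,6-trimethylphenyl in place of 2,4-difluorophenyl gives a 4.6-fold lower number from compound 2 to compound 3 (0.66 log units; beyond the scatter) and is the first single-place step read at this position. It also shows that fluorine on this aryl ring is not needed for the lower numbers seen so far, since compound 3 at 700 nM and compound 1, whose aryl group carries trifluoromethoxy, at 900 nM lie within the scatter of each other. Nothing measured here accounts for the step, so the reason for it remains unknown.

The compounds shown leave open which of the three methyl groups matter, as neither an unsubstituted phenyl nor a phenyl with a single methyl appears among them, and whether a ring is needed on the sulfur at all, as a cyclohexyl or a simple alkyl chain would test. They also leave open how the ethyl ester, kept throughout, compares with a carboxylic acid or an amide when paired with 2,4,6-trimethylphenyl on the sulfur.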